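Allyl to 4-methylbenzyl: tolerance in macrophage cells

The source may report more compounds than this note shows. Statements on the series, on what has been measured and on what is new or still open speak of the compounds shown alone.

Measured compounds:
compound 1, `C=CCn1nc(Cl)c2ccc(N/C(C)=C3\C(=O)C=C(C)OC3=O)cc21`: > 100000 nM
compound 2, `CC1=CC(=O)/C(=C(/C)Nc2ccc3c(Cl)nn(Cc4ccc(C)cc4)c3c2)C(=O)O1`: > 100000 nM
compound 3, `C=CCn1cc2ccc(N/C(C)=C3\C(=O)C=C(C)OC3=O)cc2n1`: > 100000 nM

All three were examined in an ADME assay on RAW264.7 cells (Mus musculus) for cytotoxicity, read by resazurin assay, with a stated time of 48 h; a higher number here means that more compound is tolerated, a lower number that less compound is tolerated. In this assay compound 1 gives > 100000 nM, which is a limit of the assay and not a number. Compound 2 in this assay likewise reaches only a limit, > 100000 nM. Compound 3 in this assay also sits at a limit, > 100000 nM.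

The step from compound 1 to compound 2 reads a step that the two limits leave unreadable from compound 1 to compound 2; the change behind it is 4-methylphenyl in place of vinyl on a saturated chain carbon bound to an aromatic nitrogen. Its size cannot be read because the limit of > 100000 nM in this assay, at which 3 of the 3 values shown sit, holds both ends of the pair.

Compound 4, `CC1=CC(=O)/C(=C(/C)Nc2ccc3cn(Cc4ccc(C)cc4)nc3c2)C(=O)O1`, has not been measured. It differs from compound 3 by 4-methylphenyl in place of vinyl on a saturated chain carbon bound to an aromatic nitrogen, the same change, at the same place, as that from compound 1 to compound 2. The difference between the core of compound 1 and the core of compound 3 is not broken down here.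

The step from compound 3 to compound 4 is expected to be a number no higher from compound 3 to compound 4 (the limit leaves the size open), resting beside the earlier step that the two limits leave unreadable from compound 1 to compound 2 and on (the limit of > 100000 nM in this assay, at which 3 of the 3 values shown sit). Compound 4 is accordingly estimated at 100000 nM in this assay, most probably reported again only as a limit. The expected range for compound 4 runs from 50000 nM to 300000 nM.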

Compound 4, half-maximal cytotoxic concentration: > 100000 nM
Compound 4: only a limit was reported; the forecaster's own chance of this, stated with the estimate: 85%; the middle value sits exactly at the limit.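

No size can be read for the step between compound 3 and compound 4, because both ends of that pair rest on the same limit, and the result adds no readable comparison: the limit of > 100000 nM in this assay, at which 4 of the 4 values shown sit.

The compounds shown leave open at what concentration any of them would reach half-maximal cytotoxicity in this assay, and whether allyl to 4-methylbenzyl changes tolerance at all on either core.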